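The source may hold more compounds than are shown below. What is called first, only, known or untested is meant among the compounds shown, and "the series" means these compounds.

Measured so far:
compound 1 `O=C(c1ccc(-c2nc(-c3cccnc3)no2)s1)C(F)(F)F` – 70 nM
compound 2 `O=C(c1ccc(-c2nnc(-c3ccccc3)o2)s1)C(F)(F)F` – 420 nM
compound 3 `O=C(c1ccc(-c2nc(CS(=O)(=O)c3cccs3)no2)s1)C(F)(F)F` – 35 nM

All three numbers come from an assay for inhibition of histone deacetylase 4 (Homo sapiens); on this read-out lower numbers stand for stronger inhibition and higher numbers for weaker inhibition. Compound 1 stands second highest of the three. Its nearest neighbour is compound 3, whose number lies within the scatter of that of compound 1; compound 2 lies beyond the scatter, on the higher side.

Compound 4 `Cc1ccc(-c2noc(-c3ccc(C(=O)C(F)(F)F)s3)n2)cc1` has not yet been measured. It differs from compound 1 in one place: 4-methylphenyl in place of pyridin-3-yl on an aromatic carbon. Going by the values given here, no measured pair shows this exchange, so there is nothing to read a step from directly.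

The expectation for this assay is a small step from compound 1 toward a higher number, of a 2.1-fold higher number from compound 1 to compound 4 (0.33 log units; beyond the scatter), likely not far beyond the scatter. Compound 4 is therefore estimated at 150 nM, with a range from 50 nM to 450 nM.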

Compound 4, half-maximal inhibitory concentration: 110 nM
Compound 4: the middle estimate sits 1.4-fold (0.13 log units) above what was measured; the range from low to high includes it.
By their numbers in this assay, from the lowest: compounds 3, 1 and 4 (each within the scatter of the next, the first and the last beyond it); then compound 2.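

In this assay the exchange of pyridin-3-yl for 4-methylphenyl on this aromatic carbon gives a 1.6-fold higher number from compound 1 to compound 4 (0.20 log units; within the scatter) and so shows that the position tolerates this change without a step beyond the scatter. The ring nitrogen of pyridin-3-yl is therefore not needed here to keep the number within the scatter of compound 1. Nothing measured offers an explanation for this result.

Going by these compounds alone, the single step changes the ring nitrogen and the methyl together, leaving their separate contributions open. Also open, from the compounds shown here alone, is whether an amine or a carboxylic acid on this aromatic ring would keep the number close to that of compound 1.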